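This account rests on a few compounds, and the source may have more. Where it says the series, first, only, none or still open, it means among the compounds named here.

Series of protected nucleoside sultams read in a functional assay on HEL cells (Homo sapiens) for cytotoxicity, read by microscopy; on this read-out lower numbers stand for higher toxicity in this test and higher numbers for lower toxicity in this test. Compound 1 `CCOC(=O)NC(=O)NC1=CS(=O)(=O)O[C@@]12[C@@H](CO[Si](C)(C)C(C)(C)C)O[C@@H](n1cc(C)c(=O)n(C)c1=O)[C@@H]2O[Si](C)(C)C(C)(C)C` gives 16000 nM. Compound 2 `Cc1cn([C@@H]2O[C@H](CO[Si](C)(C)C(C)(C)C)[C@@]3(OS(=O)(=O)C=C3NC(=O)c3ccccc3)[C@H]2O[Si](C)(C)C(C)(C)C)c(=O)n(C)c1=O` returns only a limit, >= 3200 nM, so the step that the limit leaves unreadable from compound 1 to compound 2 cannot be sized. Compound 2 therefore sits at the limit of >= 3200 nM in this assay, at which 1 of the 2 values shown sits, and has no numbered value. Compound 3 `Cc1cn([C@@H]2O[C@H](CO[Si](C)(C)C(C)(C)C)[C@@]3(OS(=O)(=O)C=C3NCC(=O)C(=O)O)[C@H]2O[Si](C)(C)C(C)(C)C)c(=O)n(C)c1=O` differs from compound 2 by (carboxycarbonyl)methyl in place of benzoyl on an amine nitrogen. Going by the values given here, no measured step bears on this change, and the one step recorded is unreadable, so no shift beyond the scatter is assumed; the expected step that the limit leaves unreadable from compound 2 to compound 3 is accordingly small. Compound 3 is estimated at 10000 nM, between 3200 nM and 40000 nM, with a further limit likely.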

Compound 3, minimum cytotoxic concentration: 400000 nM
Beside the measured number, compound 3's estimate is 40-fold (1.60 log units) below it, outside the stated range (above it).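

In this assay, the group on the amine nitrogen now gives a readable shift: (carboxycarbonyl)methyl in place of (ethoxycarbonyl)carbamoyl gives a 25-fold higher number from compound 1 to compound 3 (1.40 log units; beyond the scatter). Compound 1 and compound 2 alone gave no readable step at this position. The steps to and from compound 2 still cannot be read, since its value is only a limit: the limit of >= 3200 nM in this assay, at which 1 of the 3 values shown sits.

As far as these compounds go, it remains open which part of (carboxycarbonyl)methyl carries this step, the carboxylic acid or the carbonyl. From the compounds shown here alone, how an ethyl ester or a longer chain on the same nitrogen would read also remains open.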